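The source may report more compounds than this note shows. Statements on the series, on what has been measured and on what is new or still open speak of the compounds shown alone.

Compound 1 `CCCCCCCCCCn1cc(COc2nc(-c3ccccc3)nc3nc(C(F)(F)F)ccc23)nn1` gives 490 nM in a functional assay on PANC-1 cells (Homo sapiens) for antiproliferative activity, read by sulforhodamine B assay, with a stated time of 48 h; on this read-out lower numbers stand for stronger inhibition of growth and higher numbers for weaker inhibition of growth. Compound 2 `CCCCCCCCn1cc(COc2nc(-c3ccccc3)nc3nc(C(F)(F)F)ccc23)nn1` gives 2660 nM in this assay.

Going by the values given here, compound 2 stands at the highest number of the two, the weaker of the pair; its only neighbour is compound 1, with a 5.4-fold higher number from compound 1 to compound 2 (0.73 log units; beyond the scatter) showing how shortening the chain weakened growth inhibition. Compound 3 `COc1cc(-n2cc(COc3nc(-c4ccccc4)nc4nc(C(F)(F)F)ccc34)nn2)cc(OC)c1OC` carries 3,4,5-trimethoxyphenyl in place of octyl on an aromatic nitrogen. Among the compounds with values here, the single measured step concerns chain length alone, so it does not bear on swapping a chain for an aromatic ring, and the direction of the change is open. Compound 3 is estimated at 1500 nM, range 200 nM to 12000 nM, which would be an expected step of a 1.8-fold lower number from compound 2 to compound 3 (0.25 log units; within the scatter) in this assay.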

Compound 3, concentration for 50% growth inhibition: 820 nM
Estimate against measurement, compound 3: 1.8-fold (0.26 log units) above, within the range that was stated.
By their numbers in this assay, from the lowest: compounds 1 and 3 (each within the scatter of the next); then compound 2.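

Going by these compounds alone, on this aromatic nitrogen, a chain is not the only group that gives growth inhibition: 3,4,5-trimethoxyphenyl in place of octyl gives a 3.2-fold lower number from compound 2 to compound 3 (0.51 log units; beyond the scatter). Set against the longer decyl chain, the same group gives a 1.7-fold higher number from compound 1 to compound 3 (0.22 log units; within the scatter), so the two cannot be told apart in this read-out. A group with an aromatic ring and 3 hydrogen-bond acceptors therefore does about as well here as the decyl chain, which has neither.

No evidence on hand accounts for these numbers. Going by these compounds, whether the methoxy groups matter, or whether a plain phenyl or a chain ending in an amine would do as well, stays open.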